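Swapping Methoxy for Chloro on the Aniline Ring

This account rests on a few compounds, and the source may have more. Where it says the series, first, only, none or still open, it means among the compounds named here.

Compound 1 `COc1cccc(Nc2ccnc(N3CCN(C)CC3)n2)c1`: > 200000 nM in a functional assay on A549 cells (Homo sapiens) for cytotoxicity, read by MTT assay, with a stated time of 48 h; a higher number here means a weaker inhibitor, a lower number a stronger inhibitor
Compound 2 `COc1ccc(Nc2nccc(N3CCN(C)CC3)n2)cc1`: > 200000 nM in this assay

For compound 1 this value is a limit of this assay, not a number. For compound 2 the value is likewise a limit, not a number. On these data alone, compound 2 thus sits at the limit of > 200000 nM in this assay, at which 2 of the 2 values shown sit, so how weak it truly is remains unknown.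

Compound 3 `CN1CCN(c2ccnc(Nc3ccc(Cl)cc3)n2)CC1` differs from compound 2 by chloro in place of methoxy on an aromatic carbon. Among the measured compounds shown here, no measured pair shows this change, so no step can be read from data. Compound 3 is expected to give 200000 nM, between 50000 nM and 600000 nM. That expectation means a step of a number no higher from compound 2 to compound 3 (the limit leaves the size open) in this assay, none beyond the scatter.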

Compound 3, half-maximal inhibitory concentration: > 200000 nM
Compound 3: no number, only a limit; the forecaster's own chance of this, stated with the estimate: 70%; the middle value sits exactly at the limit.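

Compound 2 and compound 3 both give only a limit, not a number, so no step can be read between them: the limit of > 200000 nM in this assay, at which 3 of the 3 values shown sit.

The compounds shown leave open how weak each truly is, and whether chloro in place of methoxy changes anything in this assay at all.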